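A few compounds are considered here, and "the series" means these few. Any claim that something is new, unique, unknown or untested is made for them only; others in the source may bear on it.

Compound 1 `Nc1nc(NCCNc2ncc(-c3ncc[nH]3)c(-c3ccc(C(F)(F)F)cc3)n2)ccc1[N+](=O)[O-]`: > 0.5 h (a limit)
Compound 2 `Nc1nc(NCCNc2ncc(-c3ncc[nH]3)c(-c3ccc(Cl)cc3Br)n2)ccc1[N+](=O)[O-]`: > 0.5 h (a limit)

In an ADME assay on microsomes from liver (Canis lupus familiaris) for metabolic stability (on this read-out higher numbers stand for a longer-lived compound and lower numbers for a shorter-lived compound), compound 2 gives > 0.5 h, which is a limit and not a number. The two measured compounds share (the limit of > 0.5 h in this assay, at which 2 of the 2 values shown sit). Compound 3 `Cc1cc(Cl)ccc1-c1nc(NCCNc2ccc([N+](=O)[O-])c(N)n2)ncc1-c1ncc[nH]1` departs from compound 2 by one change, methyl in place of bromo on an aromatic carbon, ortho to a large group: methyl in place of bromo on an aromatic carbon. For the measured compounds named here, the one measured step is a step that the two limits leave unreadable from compound 1 to compound 2. It gives no size to carry over, so no step beyond the scatter, and no direction, is expected in this assay. The estimated step is a step that the limit leaves unreadable from compound 2 to compound 3. For compound 3 the estimate is 0.8 h, with an expected range from 0.4 h to 2 h.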

Compound 3, half-life: > 0.5 h
Compound 3 ended at the assay's limit (the forecaster's own chance of this, stated with the estimate: 75%); the middle value does not contradict the limit.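

No step can be read among compound 1, compound 2 and compound 3, since each gives a limit and not a number: the limit of > 0.5 h in this assay, at which 3 of the 3 values shown sit.

The compounds shown leave open how long each actually lasts in this assay, and whether methyl in place of bromo makes any difference.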